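The source may report more compounds than this note shows. Statements on the series, on what has been measured and on what is new or still open speak of the compounds shown alone.

Results in an ADME assay on microsomes from liver (Mus musculus) for metabolic stability, with a stated time of 30 min, tested at 1 uM (on this read-out higher numbers stand for a more stable compound and lower numbers for a less stable compound), so far:

Compound 1 `CC[C@@H]1C(=O)N(C)c2cnc(-n3ccnc3-c3ccccc3)nc2N1[C@@H]1CCOC1` gives 27%
Compound 2 `CC[C@@H]1C(=O)N(C)c2cnc(-n3ccnc3-c3ccc(F)cc3)nc2N1CCC(F)(F)F` gives 32%

Compound 2 stands within the usual scatter of compound 1, so the two cannot be told apart on this read-out. Compound 3 `CC[C@@H]1C(=O)N(C)c2cnc(-n3ccnc3-c3ccccc3)nc2N1CCC(F)(F)F` has yet to be measured. It departs from compound 2 by hydrogen in place of fluoro on an aromatic carbon with hydrogen in place of fluoro on an aromatic carbon, the change from 4-fluorophenyl to phenyl. Among the compounds with values here, no measured pair differs in one place alone, so the data give no direct size for this change. Compound 1 also carries phenyl but differs elsewhere too, and its 27% offers only a loose guide. A small downward move is expected, and the estimated a number 3 percentage points lower from compound 2 to compound 3 (within the scatter) stays within the scatter. In this assay compound 3 is expected at 29% within a range from 18% to 41% as a working estimate.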

Compound 3, percent of the compound remaining: 2%
Compound 3: the middle estimate sits 27 percentage points above what was measured, and the stated range ends above it.
By their numbers in this assay, from the lowest: compound 3; then compounds 1 and 2 (each within the scatter of the next).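

Hydrogen in place of fluoro on the aromatic carbon, para to a large group, gives a number 30 percentage points lower from compound 2 to compound 3 (beyond the scatter) in this assay and is the first single-place step at this position, showing that the read-out responds strongly to this one atom. With phenyl held in common, 3,3,3-trifluoropropyl in place of oxolan-3-yl on the nitrogen gives a number 25 percentage points lower from compound 1 to compound 3 (beyond the scatter) in the same assay, so the group on that nitrogen also counts. Nothing measured here accounts for either step.

As far as these compounds go, it remains open whether chloro, methoxy or a nitrile on the same aromatic carbon would keep the number near that of compound 2. From the compounds shown here alone, it is also open whether fluoro at this place would give a step of similar size with oxolan-3-yl on the nitrogen.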